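Methoxy for methyl on the benzyl of a xanthine

The source may hold more compounds than are shown below. What is called first, only, known or untested is meant among the compounds shown, and "the series" means these compounds.

Compound 1 `CCCn1c(=O)c2nc(-c3cnn(Cc4cccc(C)c4)c3)[nH]c2n(CCC)c1=O` carries a 3-methylbenzyl group on the shared core. Among the compounds with values here, in an assay on CHO cells for displacement of a labelled ligand from adenosine receptor A1 (Homo sapiens) (on this read-out higher numbers stand for weaker inhibition and lower numbers for stronger inhibition), compound 1 gives 48 nM, the only number so far; in this assay compound 2 `CCCn1c(=O)c2nc(-c3cnn(Cc4c(F)cc(F)cc4F)c3)[nH]c2n(CCC)c1=O` gives "not determined" (no result reported). Compound 3 `CCCn1c(=O)c2nc(-c3cnn(Cc4ccccc4OC)c3)[nH]c2n(CCC)c1=O` differs from compound 1 by 2-methoxyphenyl in place of 3-methylphenyl on a saturated chain carbon bound to an aromatic nitrogen. Within the data shown here, no step between measured compounds is known, so the expectation rests on compound 1 alone, and the change from compound 1 to compound 3 is expected to stay within the usual scatter, at most a slight weakening a 1.5-fold higher number from compound 1 to compound 3 (0.16 log units; within the scatter). Compound 3 is therefore estimated at 70 nM, within a range of 25 nM to 200 nM.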

Compound 3, inhibition constant: 59 nM
Compound 3: the middle estimate sits 1.2-fold (0.07 log units) above what was measured; low and high end bracket the measured number.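

In this assay the exchange of 3-methylbenzyl for 2-methoxybenzyl gives a 1.2-fold higher number from compound 1 to compound 3 (0.09 log units; within the scatter) and so leaves the result unchanged within the scatter, although the entering group adds one oxygen and one hydrogen-bond acceptor. This first readable step shows that this position accepts that exchange, but it cannot separate the change of group from the change of its place on the ring. Nothing measured on hand accounts for this result.

Steps involving compound 2 cannot be read, as it has no number. From the compounds shown here alone, whether 3-methoxybenzyl, or an amine or carboxylic acid on the benzyl ring, would also hold the value remains open.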